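This account rests on a few compounds, and the source may have more. Where it says the series, first, only, none or still open, it means among the compounds named here.

Compound 3 `Cc1n[nH]c(C)c1CN1CCN(c2cccc3[nH]c(-c4ccc(C(C)(C)C)cc4)nc23)CC1` gives 68 nM in an assay on isolated protein for displacement of a labelled ligand from Gonadotropin-releasing hormone receptor (Homo sapiens) (a lower number here means a stronger inhibitor, a higher number a weaker inhibitor), the highest of the three numbers in hand. Compound 1 `Cn1cnc(CN2CCN(c3cccc4[nH]c(-c5ccc(C(C)(C)C)cc5)nc34)CC2)c1` gives 33 nM in this assay, and compound 2 `Cc1nc(C)c(CN2CCN(c3cccc4[nH]c(-c5ccc(C(C)(C)C)cc5)nc34)CC2)o1` gives 31 nM. The two steps that separate compound 3 from its neighbours are modest but beyond the scatter: a 2.1-fold higher number from compound 1 to compound 3 (0.31 log units; beyond the scatter) and a 2.2-fold higher number from compound 2 to compound 3 (0.34 log units; beyond the scatter). By contrast a 1.1-fold lower number from compound 1 to compound 2 (0.03 log units; within the scatter) lies within the scatter, so the oxazole and the methylimidazole read the same.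

Compound 4 `CCCCn1cnc(CN2CCN(c3cccc4[nH]c(-c5ccc(C(C)(C)C)cc5)nc34)CC2)c1C` has not yet been measured. The change from compound 3 is 1-butyl-5-methyl-1H-imidazol-4-yl in place of 3,5-dimethyl-1H-pyrazol-4-yl on a saturated chain carbon bound to an amine nitrogen in a ring. The step that bears most directly on it runs the other way from the one already seen, since the imidazole of compound 1 returns, now carrying a butyl on its nitrogen and a methyl on the ring. The measured steps say that the pyrazole costs a modest amount relative to either of the other two heteroaryls, and nothing measured speaks to the butyl or the added methyl on their own.

Compound 4 is therefore expected to fall back toward the numbers of compound 1 and compound 2, a modest downward step of a 1.9-fold lower number from compound 3 to compound 4 (0.29 log units; within the scatter), with an estimated value of 35 nM, in a range from 12 nM to 100 nM.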

Compound 4, half-maximal inhibitory concentration: 46 nM
For compound 4 the middle estimate is 1.3-fold (0.12 log units) below the measured one; the range from low to high includes it.
By their numbers in this assay, from the lowest: compounds 2, 1, 4 and 3 (each within the scatter of the next, the first and the last beyond it).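

In this assay the 1-butyl-5-methyl-1H-imidazol-4-yl group on a saturated chain carbon bound to an amine nitrogen in a ring stays within the scatter of all three earlier compounds (a 1.4-fold higher number from compound 1 to compound 4 (0.14 log units; within the scatter)) (a 1.5-fold higher number from compound 2 to compound 4 (0.17 log units; within the scatter)) (a 1.5-fold lower number from compound 3 to compound 4 (0.17 log units; within the scatter)). The position therefore takes a group of 10 heavy atoms with a butyl chain, against 7 heavy atoms in the 3,5-dimethyl-1H-pyrazol-4-yl group, and the change from 1 hydrogen-bond donor to 0 brings no step beyond the scatter, while compound 4 cannot be placed on either side of the gap that separates compound 3 from compound 1 and compound 2. No supporting evidence is available to explain this reading.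

On these data alone, compound 4 differs from compound 1 in both the butyl chain and the added ring methyl, so what each contributes alone remains open. Also open, as far as these compounds go, is whether the position would read the same with a longer chain such as hexyl, or with a butyl chain ending in an amine or a carboxylic acid.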